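The source may hold more compounds than are shown below. What is called first, only, known or untested is meant among the compounds shown, and "the series" means these compounds.

Compound 1 `O=C1CC(c2nc(-c3ccccc3)no2)CN1c1ccccc1`: 350 nM
Compound 2 `O=C1CC(c2nc(-c3ccc(Cl)cc3)no2)CN1c1ccc(Cl)c(Cl)c1`: 1100 nM
Compound 3 `Cc1cccc(-c2noc(C3CC(=O)N(c4ccc(F)cc4)C3)n2)n1`: > 10000 nM

In an in vitro functional assay on HEK293-A cells for positive allosteric modulation of metabotropic glutamate receptor 5 (Homo sapiens), read by FLIPR and calcium flux (on this read-out higher numbers stand for an effect only at larger amounts of compound and lower numbers for an effect already at smaller amounts), compound 1 holds the lowest of the two numbers measured; compound 2 sits at a higher number, a gap beyond the scatter. Compound 3 gave no number at all, only the limit (the limit of > 10000 nM in this assay, at which 1 of the 3 values shown sits). Compound 4 `Cc1ccc(N2CC(c3nc(-c4ccccc4)no3)CC2=O)cc1` has not been measured; it differs from compound 1 by methyl in place of hydrogen on an aromatic carbon. Among the compounds with values here, no measured pair shows this same change, so the size of its step is unknown. The expectation is a step that stays within the scatter, in no clear direction: the expected step is a 1.1-fold higher number from compound 1 to compound 4 (0.06 log units; within the scatter). Compound 4 is therefore estimated at 400 nM, between 150 nM and 1200 nM.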

Compound 4, half-maximal effective concentration: 384 nM
Compound 4: middle estimate off by 1.0-fold (0.02 log units), on the high side, within the range that was stated.
By their numbers in this assay, from the lowest: compounds 1 and 4 (each within the scatter of the next); then compound 2. At a limit, above all of these: compound 3.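

A methyl para to a large group leaves the picture in this assay as it was, with a 1.1-fold higher number from compound 1 to compound 4 (0.04 log units; within the scatter), so compounds 1 and 4 stand within the scatter of each other. This is the first change in a single place among the compounds shown, and it shows that this position accepts a methyl in place of hydrogen with no step beyond the scatter. Nothing measured here speaks to why this is so. One methyl alone cannot say how far this holds at this position. From the compounds shown here alone, whether a longer chain, an amine or a carboxylic acid in the same place would keep the number stays open.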